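Methylating the Phenol Oxygen of Compound 3

The source may hold more compounds than are shown below. What is called first, only, known or untested is meant among the compounds shown, and "the series" means these compounds.

Compound 3 `CC(O)(C(=O)Nc1ccc(S(=O)(=O)c2cccc(O)c2)cc1)C(F)(F)F` gives 18000 nM in a functional assay (Cavia porcellus) with sulfonylurea receptors; K-ATP channels (Homo sapiens) as the target (a higher number here means a weaker inhibitor, a lower number a stronger inhibitor), the highest of the three numbers measured: compound 1 `CC(O)(C(=O)Nc1ccc(S(=O)(=O)c2ccccc2F)cc1)C(F)(F)F` gives 1300 nM and compound 2 `CC(O)(C(=O)Nc1ccc(S(=O)(=O)c2ccccc2C#N)cc1)C(F)(F)F` gives 1100 nM. The step of a 14-fold higher number from compound 1 to compound 3 (1.14 log units; beyond the scatter) and the step of a 16-fold higher number from compound 2 to compound 3 (1.21 log units; beyond the scatter) are both large, while the step of a 1.2-fold lower number from compound 1 to compound 2 (0.07 log units; within the scatter) lies within the scatter. Compound 4 `COc1cccc(S(=O)(=O)c2ccc(NC(=O)C(C)(O)C(F)(F)F)cc2)c1` differs from compound 3 by methyl in place of hydrogen on an oxygen on an aromatic ring. For the measured compounds named here, no measured step covers a change on this oxygen, so the data give no direct guide; the two large steps show only that the 3-hydroxyphenyl compound stands far above the other two. Compound 4 is therefore expected to give about 7000 nM, with a range from 2000 nM to 25000 nM, and the expected step of a 2.6-fold lower number from compound 3 to compound 4 (0.41 log units; beyond the scatter) is uncertain in its direction.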

Compound 4, half-maximal inhibitory concentration: 16000 nM
For compound 4 the middle estimate is 2.3-fold (0.36 log units) below the measured one; the measured number falls inside the stated range.
By their numbers in this assay, from the lowest: compounds 2 and 1 (each within the scatter of the next); then compounds 4 and 3 (each within the scatter of the next).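

In this assay, methyl in place of hydrogen on this oxygen gives a 1.1-fold lower number from compound 3 to compound 4 (0.05 log units; within the scatter) and so leaves compound 3 and compound 4 indistinguishable. The high number of compound 3 therefore does not depend on the hydrogen on this oxygen. The methoxy compound stands as far off as the hydroxy compound, with a 15-fold higher number from compound 2 to compound 4 (1.16 log units; beyond the scatter) and a 12-fold higher number from compound 1 to compound 4 (1.09 log units; beyond the scatter) both large.

On these data alone, whether a longer chain on this oxygen, or an amine in place of the hydroxy, would move the number remains open. No supporting evidence accounts for the result.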